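Replacing the Butoxycarbonyl Group on the Ring Amine

The source may hold more compounds than are shown below. What is called first, only, known or untested is meant among the compounds shown, and "the series" means these compounds.

Compound 1 `CC(C)(C)OC(=O)N1CCC(Oc2cccc3c2ccn3-c2ccc(S(C)(=O)=O)cc2)CC1`: 28%
Compound 2 `CC(C)OC(=O)N1CCC(Oc2ncnc3c2CCN3c2ccc(-c3cccn3C)cc2F)CC1`: 44%
Compound 3 `CCCCOC(=O)N1CCC(Oc2ncnc3c2CCN3c2ccc(S(C)(=O)=O)cc2F)CC1`: 131%

The three measured compounds were tested in a functional assay on CHO-K1 cells with Glucose-dependent insulinotropic receptor (Homo sapiens) as the target, read by a luciferase reporter, with a stated time of 5 h; on this read-out higher numbers stand for larger maximal responses and lower numbers for smaller maximal responses. Compound 3 stands highest of the three, with 131%. Its nearest neighbour is compound 2, which gives 44%, a gap beyond the scatter; the furthest is compound 1, which gives 28%, also beyond the scatter. Among the compounds with values here, no two of the measured compounds differ in only one place, so no single step between them can be read off.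

Compound 4 `CS(=O)(=O)c1ccc(N2CCc3c(OC4CCN(C5=NCCCN5)CC4)ncnc32)c(F)c1` keeps everything in compound 3 except the group on the ring amine: a group of 6 heavy atoms (4 carbon, 2 nitrogen; one six-membered non-aromatic ring with 2 hetero atoms) in place of a group of 7 heavy atoms (5 carbon, 2 oxygen; no ring), on an amine nitrogen in a ring. Within the data shown here, the butoxycarbonyl group that leaves is the one present in compound 3, the compound with the largest maximal response seen here, and nothing in the measured set shows what happens when it is exchanged for a ring-containing group of this kind on that amine.

Among the measured compounds shown here, with no measured step to lean on, the expectation for compound 4 is a decrease in this assay of moderate size, a number 46 percentage points lower from compound 3 to compound 4 (beyond the scatter). Compound 4 is therefore estimated at 85%, within a range from 40% to 130%.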

Compound 4, largest response reached (reported as percent of maximum), in percent of the reference or control that the assay uses: 66%
For compound 4 the middle estimate is 19 percentage points above the measured one; the measured number falls inside the stated range.
By their numbers in this assay, from the lowest: compound 1; then compound 2; then compound 4; then compound 3.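

In this assay, exchanging the butoxycarbonyl group on the amine nitrogen in a ring for the group with one six-membered non-aromatic ring with 2 hetero atoms gives a number 65 percentage points lower from compound 3 to compound 4 (beyond the scatter), the only single-place change among these compounds and a large one. This shows that the maximal response depends on what this ring amine carries, even when the rest of the molecule stays the same, yet the response is not abolished, as compound 4 still gives 66% with a group that has no oxygen atoms and has a hydrogen-bond donor. Nothing measured here bears on why the response falls with this exchange.

As far as these compounds go, this single step swaps the open butoxycarbonyl group for a ring, removes both oxygen atoms and adds a hydrogen-bond donor all at once, so the share of each change in the fall remains open. The compounds shown also leave open how an acetyl group, a pyrimidine ring or a longer chain such as hexyloxycarbonyl on the same amine would compare with butoxycarbonyl on the core of compound 3.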